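Morpholine to dimethylamine on the amide of compound 3

The compounds below may be only part of what the source reports. "The series", "measured", "known", "first", "only" and "open" are said of these compounds alone.

Measured in an in vitro ADME assay on microsomes from liver (Homo sapiens) for metabolic stability; a higher number here means faster removal of the compound, a lower number slower removal:
- compound 1 `CC[C@H](C)[C@@H]1C(=O)N[C@H](C2Cc3ccccc3C2)C(=O)N1[C@@H](C(=O)N1CCOCC1)c1ccc(C)nc1`: 3 mL.min-1.g-1
- compound 2 `Cc1ccc([C@H](C(=O)N(C)C)N2C(=O)[C@@H](C3Cc4ccccc4C3)NC(=O)[C@H]2CC(C)C)cn1`: 11000 mL.min-1.g-1
- compound 3 `CCC(CC)[C@@H]1C(=O)N[C@H](C2Cc3ccccc3C2)C(=O)N1[C@@H](C(=O)N1CCOCC1)c1ccc(C)nc1`: 12 mL.min-1.g-1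

Compound 3 stands second highest of the three numbers. Among the measured compounds shown here, its nearest neighbour is compound 1, which in this assay gives 3 mL.min-1.g-1; the one step known between measured compounds is a 4.0-fold higher number from compound 1 to compound 3 (0.60 log units; beyond the scatter). Furthest off is compound 2, which gives 11000 mL.min-1.g-1; compound 2 differs from compound 3 in more than one place, so no single step is drawn between them.

Compound 4 `CCC(CC)[C@@H]1C(=O)N[C@H](C2Cc3ccccc3C2)C(=O)N1[C@@H](C(=O)N(C)C)c1ccc(C)nc1` is not yet measured. Relative to compound 3 the change is dimethylamino in place of morpholin-4-yl on a carbonyl carbon.

For the measured compounds named here, no measured step isolates this exchange. Going by the values given here, the only compound carrying a dimethylcarbamoyl group is compound 2, whose value in this assay is 11000 mL.min-1.g-1, far above compound 3, but its other differences from compound 3 leave the share of the amide change unknown. The direction is therefore expected upward and the size of the step uncertain; the expected step is a 67-fold higher number from compound 3 to compound 4 (1.82 log units; beyond the scatter). Compound 4 is estimated at 800 mL.min-1.g-1, within 100 mL.min-1.g-1 to 8000 mL.min-1.g-1.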

Compound 4, intrinsic clearance in microsomes: 11 mL.min-1.g-1
Compound 4: middle estimate off by 73-fold (1.86 log units), on the high side, and the stated range ends above it.
By their numbers in this assay, from the lowest: compound 1; then compounds 4 and 3 (each within the scatter of the next); then compound 2.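

In this assay, with pentan-3-yl held on the saturated ring carbon, dimethylamino in place of morpholin-4-yl on a carbonyl carbon gives a 1.1-fold lower number from compound 3 to compound 4 (0.04 log units; within the scatter) and so does not separate the two amides. With dimethylamino held, the change from isobutyl to pentan-3-yl gives a 1000-fold lower number from compound 2 to compound 4 (3.00 log units; beyond the scatter) in the same read-out, so the dimethylcarbamoyl group alone does not bring the high number of compound 2. Nothing shown here accounts for either step.

Still open, from the compounds shown here alone, is whether the amide exchange gives the same result with sec-butyl or isobutyl on the saturated ring carbon. Also open, going by these compounds, is whether a smaller or differently shaped amine on the carbonyl carbon, such as azetidin-1-yl or piperidin-1-yl, would track with morpholin-4-yl and dimethylamino.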